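The source may report more compounds than this note shows. Statements on the series, on what has been measured and on what is new or still open speak of the compounds shown alone.

- compound 1 `Cc1ccc2c(c1)/C(=N/NC(=S)NO)C(=O)N2CN(C)C` measured at 651000 nM 
- compound 2 `CCn1cc(C(=O)O)c(=O)c2cc(F)c(N3CCN(CN4C(=O)/C(=N\NC(=S)NO)c5cc(C)ccc54)CC3)cc21` measured at 327000 nM 
- compound 3 `CONC(=S)N/N=C1\C(=O)N(CN2CCN(c3ccccc3)CC2)c2ccc(C)cc21` measured at 276000 nM 

All three values come from an ADME assay on MT4 cells (Homo sapiens) for cytotoxicity, read by spectrophotometry, with a stated time of 5 days (a lower number here means that less compound is tolerated, a higher number that more compound is tolerated), and are half-maximal cytotoxic concentrations. Compound 2 at 327000 nM lies within the usual scatter of both compound 1 and compound 3, so on these numbers it cannot be separated from either of them. Compound 4 `CCn1cc(C(=O)O)c(=O)c2cc(F)c(N3CCN(CN4C(=O)/C(=N\NC(=S)NO)c5cc(Cl)ccc54)CC3)cc21` is compound 2 with chloro in place of methyl on an aromatic carbon, and chloro in place of methyl on an aromatic carbon sums up the swap. That carbon belongs to a six-membered aromatic ring of carbon only, part of a fused or bridged system of two rings. For the measured compounds named here, no two measured compounds differ in one place only, so the data give no direct size for such a swap. In this assay no step beyond the scatter is expected, and the estimated change is a 1.1-fold lower number from compound 2 to compound 4 (0.04 log units; within the scatter) for this swap. This expectation leans on compound 2 at 327000 nM as the closest measured relative. For compound 4 the expected value is 300000 nM with a likely range from 140000 nM to 620000 nM in this measurement.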

Compound 4, half-maximal cytotoxic concentration: 186000 nM
Beside the measured number, compound 4's estimate is 1.6-fold (0.21 log units) above it; measured number inside the range.
By their numbers in this assay, from the lowest: compounds 4, 3, 2 and 1 (each within the scatter of the next, the first and the last beyond it).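

For the compounds shown here, this pair gives the first direct reading of a swap at this position: in this assay, chloro in place of methyl on the aromatic carbon gives a 1.8-fold lower number from compound 2 to compound 4 (0.25 log units; within the scatter). With the rest of the molecule unchanged, the two groups cannot be told apart in this cell test, so this one pair gives no sign that the choice between them matters here. Nothing given here explains this result.

A single pair cannot show whether the same swap would read alike in compound 1 or compound 3, which differ from compound 2 elsewhere in the molecule. It also leaves open how a group of a different kind on this aromatic carbon, such as an amine or a nitrile, would read in this assay.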